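The source may hold more compounds than are shown below. What is called first, only, known or untested is meant among the compounds shown, and "the series" means these compounds.

Measured compounds:
compound 1 `C=C(Br)C(=O)Nc1cccc(-c2cn3nc(-c4ccc(OCC)cc4)sc3n2)c1` — 1400 nM
compound 2 `Nc1cccc(-c2cn3c(-c4ccc(Cl)cc4)csc3n2)c1` — 21000 nM
compound 3 `Nc1cccc(-c2cn3nc(-c4ccc(F)cc4)sc3n2)c1` — a limit only, >= 250000 nM

In a functional assay on CCRF-CEM cells (Homo sapiens) for inhibition, read by cell counting, with a stated time of 3 days (on this read-out lower numbers stand for stronger inhibition and higher numbers for weaker inhibition), compound 1 holds the lowest of the two numbers; its nearest neighbour, compound 2, sits well beyond the scatter. Compound 3 returns only a limit of the assay, (the limit of >= 250000 nM in this assay, at which 1 of the 3 values shown sits). Going by the values given here, no pair among the measured compounds differs in a single place, so no measured step is available.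

Compound 4 `C=C(Br)C(=O)Nc1cccc(-c2cn3nc(-c4ccccc4)sc3n2)c1` differs from compound 1 by hydrogen in place of ethoxy on an aromatic carbon. Among the compounds with values here, with no measured step to lean on, the expectation in this assay is a modest move toward weaker inhibition, around the edge of the scatter. Compound 4 is expected near 2800 nM (range 900 nM to 9000 nM), which would make the step of a 2.0-fold higher number from compound 1 to compound 4 (0.30 log units; within the scatter).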

Compound 4, half-maximal inhibitory concentration: 960 nM
The estimate for compound 4 lay 2.9-fold (0.46 log units) above the measured number, within the range that was stated.
By their numbers in this assay, from the lowest: compounds 4 and 1 (each within the scatter of the next); then compound 2. At a limit, above all of these: compound 3.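

Replacing 4-ethoxyphenyl with phenyl in this assay gives a 1.5-fold lower number from compound 1 to compound 4 (0.16 log units; within the scatter). The ethoxy on this aromatic carbon, para to a large group, is therefore not required for a number in this range: the plain phenyl and the ethoxy-bearing compound cannot be told apart here. Nothing at hand accounts for this outcome.

As far as these compounds go, only hydrogen and ethoxy have been compared at this carbon, so the effect of a carboxylic acid, an amine or a longer chain such as butoxy remains open. Whether the same insensitivity holds when the rest of the molecule changes is also unresolved.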